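A few compounds are considered here, and "the series" means these few. Any claim that something is new, unique, unknown or untested is made for them only; others in the source may bear on it.

Working notes on the series. Two compounds have numbers in a functional assay on SW-620 cells (Homo sapiens) for inhibition, read by MTT assay, with a stated time of 48 h; on this read-out lower numbers stand for stronger inhibition and higher numbers for weaker inhibition. Compound 1 `Cc1ccc(COc2ccc(C(=O)NC(=O)Nc3ccc(C)c(-c4nc5ccccc5[nH]4)c3)cc2)cc1` gives 26000 nM in this assay. Compound 2 `Cc1ccc(NC(=O)NC(=O)c2ccc(OCc3ccccc3Cl)cc2)cc1-c1nc2ccccc2[nH]1` gives 35700 nM in this assay. Going by the values given here, the one step measured so far, a 1.4-fold higher number from compound 1 to compound 2 (0.14 log units; within the scatter), exchanges 2-chlorophenyl for 4-methylphenyl on the saturated chain carbon bound to the oxygen on the aromatic ring. Of the two numbers in hand, compound 2 holds the higher one, but its nearest neighbour is compound 1 and that gap lies within the scatter, so the two cannot be told apart.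

Compound 3 `Cc1ccc(NC(=O)NC(=O)c2ccc(OCc3ccc(Cl)cc3Cl)cc2)cc1-c1nc2ccccc2[nH]1` is not yet measured. It differs from compound 2 by chloro in place of hydrogen on an aromatic carbon. Among the compounds with values here, the only step that bears on it is the one from compound 1 to compound 2, which also alters substituents on this same benzyl ring and came out within the scatter. On that basis no step beyond the scatter is expected in this assay for compound 3, in either direction, and the step of a 1.1-fold lower number from compound 2 to compound 3 (0.05 log units; within the scatter) is expected to be small. Compound 3 is estimated to give 32000 nM, with a range from 12000 nM to 90000 nM.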

Compound 3, half-maximal inhibitory concentration: 12200 nM
Estimate against measurement, compound 3: 2.6-fold (0.42 log units) above; the range from low to high includes it.
By their numbers in this assay, from the lowest: compound 3; then compounds 1 and 2 (each within the scatter of the next).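

In this assay, going by these compounds alone, chloro on the aromatic carbon para to a large group and meta to the chloro group gives a 2.9-fold lower number from compound 2 to compound 3 (0.47 log units; beyond the scatter), the first step at this benzyl ring to lie beyond the scatter, though a modest one. The 2,4-dichlorophenyl group also separates from the 4-methylphenyl group, with a 2.1-fold lower number from compound 1 to compound 3 (0.33 log units; beyond the scatter), whereas the 2-chlorophenyl and 4-methylphenyl groups could not be told apart in a 1.4-fold higher number from compound 1 to compound 2 (0.14 log units; within the scatter), so compound 3 now has the lowest number of the three, and the ring does respond to substitution on this read-out. No measurement in hand accounts for the size of either step.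

The compounds shown leave open whether chloro on this carbon gives a step of this size without the 2-chloro group, or whether the step depends on the pair. They also leave open whether fluoro, methoxy or trifluoromethyl on the same carbon would move the number in the same direction, and whether a further step of this kind could bring the series well below the values seen so far.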